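This account rests on a few compounds, and the source may have more. Where it says the series, first, only, none or still open, it means among the compounds named here.

The measured compounds and their numbers:

Compound 1 `O=C(Nc1ccc([N+](=O)[O-])cc1)c1cc(Cl)ccc1O`: 127 10^-6 cm/s
Compound 2 `O=C(Nc1ccc([N+](=O)[O-])c(Cl)c1)c1cc(Cl)ccc1O`: 68 10^-6 cm/s
Compound 3 `O=C(Nc1ccc(F)cc1Cl)c1cc(Cl)ccc1O`: 50.5 10^-6 cm/s

All three were tested in an ADME assay for permeability, using PAMPA; a higher number here means that the compound crosses the layer faster, a lower number that the compound crosses the layer more slowly. Compound 1 and compound 2 differ in one place, and the change is chloro in place of hydrogen on an aromatic carbon. The step that it made is a 1.9-fold lower number from compound 1 to compound 2 (0.27 log units; within the scatter). Compound 3 stands apart from compound 1; the difference between the two cores is not broken down here, and its number is close to that of compound 2.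

Compound 4 `O=C(Nc1c(Cl)cc(F)cc1Cl)c1cc(Cl)ccc1O` has not yet been measured in this assay. It differs from compound 3 by chloro in place of hydrogen on an aromatic carbon. This is the same kind of change as from compound 1 to compound 2, but the surroundings differ: there the entering chloro sat ortho to a nitro group and meta to a large group, here it sits ortho to a large group and meta to a chloro group and meta to a fluoro group.

The expected step is a 1.4-fold lower number from compound 3 to compound 4 (0.16 log units; within the scatter), modest, resting on the earlier step of a 1.9-fold lower number from compound 1 to compound 2 (0.27 log units; within the scatter) made by the same kind of change. For compound 4 the estimate is 35 10^-6 cm/s, likely between 18 10^-6 cm/s and 70 10^-6 cm/s.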

Compound 4, apparent permeability: 25 10^-6 cm/s
Compound 4: the middle estimate sits 1.4-fold (0.15 log units) above what was measured, and the stated range covers the measured number.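

In this assay, chloro in place of hydrogen on an aromatic carbon gave a 2.0-fold lower number from compound 3 to compound 4 (0.31 log units; beyond the scatter), so the number fell again when this change was made on a second core. Placed beside the earlier step, the new one shows that the change carried over with much the same size, even though its surroundings were different: the same change on two cores in this assay, a 1.9-fold lower number (0.27 log units; within the scatter) from compound 1 to compound 2 and a 2.0-fold lower number (0.31 log units; beyond the scatter) from compound 3 to compound 4, 1.1-fold (0.03 log units) apart, within the scatter of two such steps. Among the compounds shown here, this is still only two pairs of compounds, and only the newer step lies beyond the scatter by itself, so the result does not show that the change would behave the same way on every core, nor does it explain why the number falls.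

The compounds shown leave open whether a different group at the same place, such as a methyl, a methoxy or an amine, would give a step of similar size. They also leave open how a chloro would behave on a core that carries neither a nitro group nor a fluoro group.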